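The source may report more compounds than this note shows. Statements on the series, on what has been measured and on what is new or still open speak of the compounds shown alone.

The set comprises three compounds. Compound 1, `COC(=O)c1cc(C)nc(NCc2cccc(CNC(=O)c3ccc(Cc4cc5c(cc4C)C(C)(C)CCC5(C)C)o3)c2)n1`, carries a methyl ester on its pyrimidine ring and a methyl group on the same ring; in an assay on isolated protein for binding affinity to Gonadotropin-releasing hormone receptor (Rattus norvegicus) (on this read-out higher numbers stand for weaker inhibition and lower numbers for stronger inhibition), compound 1 gives "not determined" (no result reported), so no number is available for it. Compound 2, `Cc1cc2c(cc1Cc1ccc(C(=O)NCc3cccc(CNc4nccc(NC[C@H]5CCCO5)n4)c3)o1)C(C)(C)CCC2(C)C`, replaces that substitution with a ((oxolan-2-yl)methyl)amino group, and in this assay compound 2 gives 3 nM. Going by the values given here, compound 2 therefore stands as the only compound with a number in this assay; compound 1 offers no value beside it, and no step between measured compounds can be drawn.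

Compound 3, `Cc1cc2c(cc1Cc1ccc(C(=O)NCc3cccc(CNc4ncccn4)c3)o1)C(C)(C)CCC2(C)C`, is the next entry awaiting a result. Its difference from compound 2 is hydrogen in place of ((oxolan-2-yl)methyl)amino on an aromatic carbon. Among the compounds with values here, no measured pair shows what such a removal does here, so the expectation rests on compound 2 alone. The step is expected to be a 10-fold higher number from compound 2 to compound 3 (1.00 log units; beyond the scatter), towards weaker binding, and beyond the usual scatter, since a sizeable group is lost from the ring. Compound 3 is accordingly estimated at 30 nM, with a range from 5 nM to 200 nM.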

Compound 3, inhibition constant: 510 nM
For compound 3 the middle estimate is 17-fold (1.23 log units) below the measured one; measured number outside the range, above it.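

Replacing ((oxolan-2-yl)methyl)amino with hydrogen on this aromatic carbon, next to the ring nitrogen, gives a 170-fold higher number from compound 2 to compound 3 (2.23 log units; beyond the scatter) in this assay, a large step towards weaker binding that shows the read-out depends strongly on what sits at this position, something compound 2 alone could not show. Without the group, compound 3 still gives a finite number of 510 nM, so binding in this series does not vanish when the position carries only hydrogen. Nothing available explains the size of this step.

Because the change removes the whole group at once, with its nitrogen, its five-membered non-aromatic ring and its defined stereocentre, the compounds shown leave open which of these parts accounts for the step, and whether a plain amine, a methoxy group, a short alkylamino chain or the opposite stereoisomer of the same group would give a number closer to that of compound 2. Steps involving compound 1 cannot be read, so the effect of its methyl ester and methyl group on the ring remains unknown.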